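Tert-butoxycarbonyl for methyl on compound 3

The source may hold more compounds than are shown below. What is called first, only, known or untested is meant among the compounds shown, and "the series" means these compounds.

Measured in a functional assay on MCF7 cells (Homo sapiens) for inhibition, read by CCK-8 assay, with a stated time of 48 h; on this read-out lower numbers stand for stronger inhibition of growth and higher numbers for weaker inhibition of growth:
- compound 1 `Cc1ccccc1Nc1nc(Nc2cccnc2)ncc1Cl`: 56500 nM
- compound 2 `Cc1ccc(Nc2ncc(Cl)c(Nc3ccccc3C)n2)cc1`: > 100000 nM (a limit, not a number)
- compound 3 `Cc1ccccc1Nc1nc(Nc2ccc(N3CCN(C)CC3)cc2)ncc1Cl`: 20600 nM

Of the two actual numbers, the lower belongs to compound 3 at 20600 nM, and the gap to compound 1 lies beyond the scatter. Compound 4 `Cc1ccccc1Nc1nc(Nc2ccc(N3CCN(C(=O)OC(C)(C)C)CC3)cc2)ncc1Cl` carries tert-butoxycarbonyl in place of methyl on an amine nitrogen in a ring. Among the compounds with values here, no measured step changes the group on that nitrogen. The nearest guide is the arrival of 4-methylpiperazin-1-yl in an at least 4.8-fold lower number from compound 2 to compound 3 (0.68 log units; beyond the scatter), while an at least 1.7-fold higher number from compound 1 to compound 2 (0.24 log units; that floor lies within the scatter) concerns a different place. In this assay a modest rise is therefore expected, giving back part of that drop. The expected step is a 2.2-fold higher number from compound 3 to compound 4 (0.34 log units; beyond the scatter). For compound 4 the estimate is 45000 nM, with an expected range of 15000 nM to 100000 nM.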

Compound 4, concentration for 50% growth inhibition: 2250 nM
Compound 4: middle estimate off by 20-fold (1.30 log units), on the high side; the measured number lies below the stated range.
By their numbers in this assay, from the lowest: compound 4; then compound 3; then compound 1. At a limit, above all of these: compound 2.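

In this assay, within the data shown here, the group on the amine nitrogen in the six-membered non-aromatic ring proves a strong lever, which the earlier compounds could not show: tert-butoxycarbonyl in place of methyl gives a 9.2-fold lower number from compound 3 to compound 4 (0.96 log units; beyond the scatter). This nitrogen therefore accepts a much larger group, and inhibition of growth improves rather than being lost. Nothing measured here accounts for the change.

From the compounds shown here alone, whether the gain depends on the carbonyl or on the tert-butyl part remains open. Acetyl, tert-butyl or a plain hydrogen on this nitrogen would separate these possibilities.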